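Replacing the nitro group of compound 2

The source may report more compounds than this note shows. Statements on the series, on what has been measured and on what is new or still open speak of the compounds shown alone.

Measured so far in a functional assay on the whole organism with Rattus norvegicus as the target; on this read-out higher numbers stand for an effect only at larger amounts of compound and lower numbers for an effect already at smaller amounts:
- compound 1 `CCOC(=O)C(=O)Nc1nc(-c2ccc(OC)cc2)cs1`: about 10 mg/kg
- compound 2 `CCOC(=O)C(=O)Nc1nc(-c2ccc([N+](=O)[O-])cc2)cs1`: > 100 mg/kg, a limit

Compound 2 stands at > 100 mg/kg, which is a limit of this assay and not a number. Compound 3 `CCOC(=O)C(=O)Nc1ccc(-c2csc(NC(=O)C(=O)OCC)n2)cc1` differs from it as follows: ((ethoxycarbonyl)carbonyl)amino in place of nitro on an aromatic carbon. The change lies on an aromatic carbon of a six-membered aromatic ring of carbon only, para to a large group. Going by the values given here, one measured step bears on it, an at least 10-fold higher number from compound 1 to compound 2 (1.00 log units; beyond the scatter), which lies beyond the scatter and also concerns the nitro group. Compound 1 shows at about 10 mg/kg that a number can be obtained with another group in place of nitro. Among the compounds with values here, no measured compound yet carries the entering group, so the size remains uncertain. The expected step is an at least 4.0-fold lower number from compound 2 to compound 3 (0.60 log units; beyond the scatter), toward a lower number and possibly no larger than the measured one. Compound 3 is expected at 25 mg/kg, with an estimated range from 5 mg/kg to 100 mg/kg.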

Compound 3, dose for half-maximal effect: > 30 mg/kg
Compound 3 gave a limit, no number (the forecaster's own chance of this, stated with the estimate: 30%); middle value at least 1.2-fold (0.07 log units) away from the limit.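

In this assay compound 3 gives > 30 mg/kg, which is a limit and not a number. The step between compound 2 and compound 3 cannot be read, as both ends are limits. Going by these compounds alone, putting ((ethoxycarbonyl)carbonyl)amino in place of methoxy gives an at least 3.0-fold higher number from compound 1 to compound 3 (0.47 log units; beyond the scatter), so a second group at this position, and one with no likeness to nitro in its count of heavy atoms, also falls short of methoxy, which remains the only group here with a number.

On these data alone, whether compound 3 truly stands nearer to compound 1 or to compound 2 stays open, and so does whether any group at this position can reach a lower number than methoxy. A free amine or a carboxylic acid on this aromatic carbon would be the next groups to read in this assay.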